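The source may hold more compounds than are shown below. What is called first, only, known or untested is meant among the compounds shown, and "the series" means these compounds.

Of the compounds shown here, three measured so far share one core. Compound 1 `O=C1/C(=C/c2cccnc2)CNC/C1=C\c1ccccc1F` gives 21000 nM in a functional assay on HepG2 cells (Homo sapiens) for cytotoxicity, read by MTT assay, with a stated time of 24 h; a higher number here means a weaker inhibitor, a lower number a stronger inhibitor. Compound 2 `O=C1/C(=C/c2cccnc2)CN(S(=O)(=O)c2ccccc2)C/C1=C\c1ccccc1F` gives 8210 nM in this assay, which is a 2.6-fold lower number from compound 1 to compound 2 (0.41 log units; beyond the scatter). Compound 3 `O=C1/C(=C/c2cccnc2)CN(S(=O)(=O)c2ccc([N+](=O)[O-])cc2)C/C1=C\c1ccccc1F` gives 12800 nM in this assay. Compound 2 thus holds the lowest number of the three, set apart from compound 1 beyond the scatter but from compound 3 only within it, so no ranking between compound 2 and compound 3 is claimed.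

Compound 4 `O=C1/C(=C/c2cccnc2)CN(S(=O)(=O)c2ccccc2)C/C1=C\c1ccccc1C(F)(F)F` differs from compound 2 by trifluoromethyl in place of fluoro on an aromatic carbon. Within the data shown here, no measured step alters a substituent on this aromatic ring; the one change on an aromatic carbon, a 1.6-fold higher number from compound 2 to compound 3 (0.19 log units; within the scatter), concerned a different group and stayed within the scatter. Compound 4 is therefore expected to show a 1.0-fold lower number from compound 2 to compound 4 (0.01 log units; within the scatter), no more than the scatter. The estimate for compound 4 is 8000 nM, range 3000 nM to 25000 nM.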

Compound 4, half-maximal inhibitory concentration: 5370 nM
Compound 4: the middle estimate sits 1.5-fold (0.17 log units) above what was measured; the range from low to high includes it.
By their numbers in this assay, from the lowest: compounds 4, 2, 3 and 1 (each within the scatter of the next, the first and the last beyond it).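

Among these compounds, the only measured change on this aromatic ring, 2-fluorophenyl to 2-(trifluoromethyl)phenyl, gives a 1.5-fold lower number from compound 2 to compound 4 (0.18 log units; within the scatter) in this assay. At this place, ortho to a large group, trifluoromethyl with its 4 heavy atoms therefore stands in for fluoro with its 1 without a shift beyond the scatter. No available evidence bears on the reason for this result.

One step leaves open whether a methoxy group, an amine or a carboxylic acid here would move the number beyond the scatter. On these data alone, whether this change reads alike on the core of compound 1 or compound 3 also remains open.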